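A few compounds are considered here, and "the series" means these few. Any claim that something is new, unique, unknown or untested is made for them only; others in the source may bear on it.

In an ADME assay on cells (Fibroblast) for cytotoxicity (on this read-out higher numbers stand for weaker inhibition and lower numbers for stronger inhibition), compound 1 `O=C(CCCSC[C@H](NC(=O)c1ccc(Br)cc1)C(=O)NCc1ccccc1)NO` gives 830 nM and compound 2 `O=C(/C=C\c1ccccc1)N[C@@H](CSCCCC(=O)NO)C(=O)NCc1ccccc1` gives 800 nM, with a 1.0-fold lower number from compound 1 to compound 2 (0.02 log units; within the scatter). Compound 3 `CN(C)c1ccc(C(=O)N[C@@H](CSCCCC(=O)NO)C(=O)NCc2ccccc2)cc1` has the lowest number of the three, at 350 nM. Compound 4 `CN(C)c1ccc(NC(=O)[C@H](CSCCCC(=O)NO)NC(=O)c2ccc(N(C)C)cc2)cc1` differs from compound 3 in one place: 4-(dimethylamino)phenyl in place of benzyl on an amide-type nitrogen. For the measured compounds named here, no measured step changes anything on that amide-type nitrogen, so the evidence is indirect. The nearest clue is that 4-(dimethylamino)phenyl entering on a carbonyl carbon gave a 2.3-fold lower number from compound 2 to compound 3 (0.36 log units; beyond the scatter), while dimethylamino in place of bromo gave a 2.4-fold lower number from compound 1 to compound 3 (0.38 log units; beyond the scatter). A modest move to a lower number is therefore expected, with a 1.6-fold lower number from compound 3 to compound 4 (0.20 log units; within the scatter). Compound 4 is estimated at 220 nM, within a range of 70 nM to 700 nM.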

Compound 4, half-maximal inhibitory concentration: 600 nM
Estimate against measurement, compound 4: 2.7-fold (0.44 log units) below; the range from low to high includes it.
By their numbers in this assay, from the lowest: compounds 3, 4, 2 and 1 (each within the scatter of the next, the first and the last beyond it).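

For the compounds shown here, the first change on this amide-type nitrogen, 4-(dimethylamino)phenyl in place of benzyl, gives in this assay a 1.7-fold higher number from compound 3 to compound 4 (0.23 log units; within the scatter) and so stays within the scatter. On a carbonyl carbon, the same group came with a 2.3-fold lower number from compound 2 to compound 3 (0.36 log units; beyond the scatter), a step beyond the scatter, so its effect on the number is not the same at both places. Nothing measured here offers an explanation for this result.

Still open, on these data alone, is how a plain phenyl or a longer phenylethyl chain on that nitrogen would read in this assay, and whether any group there can move the number beyond the scatter.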